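Bromo for hydrogen on the shared core in two pairs

A few compounds are considered here, and "the series" means these few. Any claim that something is new, unique, unknown or untested is made for them only; others in the source may bear on it.

Compound 1 `N#C/C(=C\C=C(/Cl)c1ccc(Br)cc1)C(=O)c1c[nH]c2ccccc12` in a functional assay for inhibition, with a stated time of 30 min, tested at 1 mM (on this read-out higher numbers stand for more inhibition at the one concentration tested (going by the name of the read-out) and lower numbers for less inhibition), gives 18.4%. Compound 2 `COc1ccc(/C(Cl)=C/C=C(\C#N)C(=O)c2c[nH]c3ccccc23)cc1OC` in this assay gives 15.8%, and the two values lie within the usual scatter of one another, so nothing separates them. The difference between the core of compound 1 and the core of compound 2 is not broken down here.

Compound 3 `COc1ccc(/C(Cl)=C/C=C(\C#N)C(=O)c2c[nH]c3ccc(Br)cc23)cc1OC` in this assay gives 11.8%. The change from compound 2 to compound 3 is bromo in place of hydrogen on an aromatic carbon and the step it made is a number 4 percentage points lower from compound 2 to compound 3 (within the scatter), which is no change that the measurement can resolve.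

Compound 4 `N#C/C(=C\C=C(/Cl)c1ccc(Br)cc1)C(=O)c1c[nH]c2ccc(Br)cc12` has not yet been measured in this assay. It differs from compound 1 by bromo in place of hydrogen on an aromatic carbon The place is described in the same words as for the pair of compound 2 and compound 3, so this is the same change, now made on the core of compound 1. Only this one earlier case of the change is available, and its step lay within the scatter.

The step from compound 1 to compound 4 in this assay is therefore estimated at a number 3.4 percentage points lower from compound 1 to compound 4 (within the scatter), beside the earlier one, because a number 4 percentage points lower from compound 2 to compound 3 (within the scatter) showed no resolvable effect of the same change. Compound 4 is expected in this assay to give about 15%, most likely between 6% and 25%.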

Compound 4, a percentage reported as inhibition, at one concentration (the size of the read-out at that concentration, not a potency): 15.8%
For compound 4 the middle estimate is 0.8 percentage points below the measured one, and the stated range covers the measured number.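

Bromo in place of hydrogen on the core of compound 1 comes out in this assay as a number 2.6 percentage points lower from compound 1 to compound 4 (within the scatter) and so has no effect that this measurement can resolve. This does not show that the change is without effect on other cores, nor does it fix a size for the effect: both cases are steps within the scatter, read at one concentration, and that read-out is not a potency. What the two pairs do show is that the change behaves alike on the two cores, with nothing to tell the steps apart: the same change on two cores in this assay, a number 4 percentage points lower (within the scatter) from compound 2 to compound 3 and a number 2.6 percentage points lower (within the scatter) from compound 1 to compound 4, 1.4 percentage points apart, within the scatter of two such steps

The compounds shown hold only hydrogen or bromo at this place on the shared core, so it remains open whether a different group there, such as an amine, a carboxylic acid or a longer chain, would give a step beyond the scatter. Also open, from the compounds shown here alone, is what each part of the difference between the core of compound 1 and the core of compound 2 contributes, and whether replacing the nitrile or the chloro group, which all four compounds share, would alter the inhibition.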